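From Methyl to Trifluoromethyl on Compound 3

The compounds below may be only part of what the source reports. "The series", "measured", "known", "first", "only" and "open" are said of these compounds alone.

In an ADME assay on HEK-293T cells (Homo sapiens) for cytotoxicity, read by MTT assay, with a stated time of 24 h (a lower number here means that less compound is tolerated, a higher number that more compound is tolerated), compound 1 (`Cc1ccc(-c2nn(-c3ccccc3)cc2-c2nc3ccccc3[nH]2)cc1`) gives 187000 nM and compound 2 (`Cc1ccc(-c2nn(-c3ccccc3)cc2-c2nc3ccccc3n2S(=O)(=O)c2ccc(C)cc2)cc1`) gives 79300 nM with its added sulfonyl group. These two are separated by a 2.4-fold lower number from compound 1 to compound 2 (0.37 log units; beyond the scatter) and that gap lies beyond the scatter. Compound 3 (`Cc1ccc(-c2nn(-c3ccccc3)cc2-c2nc3ccccc3n2S(=O)(=O)c2ccc(F)cc2)cc1`) gives 128000 nM and sits within the scatter of both: the data show a 1.5-fold lower number from compound 1 to compound 3 (0.16 log units; within the scatter) and a 1.6-fold higher number from compound 2 to compound 3 (0.21 log units; within the scatter) in the same test.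

Compound 4 (`O=S(=O)(c1ccc(F)cc1)n1c(-c2cn(-c3ccccc3)nc2-c2ccc(C(F)(F)F)cc2)nc2ccccc21`) differs from compound 3 in one place, with trifluoromethyl in place of methyl on an aromatic carbon so that 4-methylphenyl becomes 4-(trifluoromethyl)phenyl. For the measured compounds named here, no measured compound varies that group. The nearest evidence is the exchange of fluoro for methyl on the sulfonyl group's ring, seen as a 1.6-fold higher number from compound 2 to compound 3 (0.21 log units; within the scatter) and within the scatter, but it lies at a different site and is only a loose guide. The sulfonyl steps from compound 1 concern another change altogether.

Resting on that one small step, no change beyond the scatter is expected, and the estimate amounts to a 1.1-fold lower number from compound 3 to compound 4 (0.05 log units; within the scatter) as the expected step. For compound 4 the estimated value is 115000 nM with an expected range from 50000 nM to 250000 nM in this test.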

Compound 4, half-maximal cytotoxic concentration: 157000 nM
Beside the measured number, compound 4's estimate is 1.4-fold (0.14 log units) below it; measured number inside the range.
By their numbers in this assay, from the lowest: compounds 2, 3, 4 and 1 (each within the scatter of the next, the first and the last beyond it).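

In this assay the exchange of methyl for trifluoromethyl reads as a 1.2-fold higher number from compound 3 to compound 4 (0.09 log units; within the scatter) and gives the only view of this position, since compound 1, compound 2 and compound 3 all carry the 4-methylphenyl group there. It shows that, with the (4-fluorophenyl)sulfonyl group in place, this assay does not separate 4-methylphenyl from 4-(trifluoromethyl)phenyl, even though the entering group is larger by the count of heavy atoms. Nothing in the data accounts for this result, and a single pair cannot show whether the same holds elsewhere in the series.

The compounds shown leave open whether the same exchange would also stay within the scatter with the hydrogen of compound 1 or the (4-methylphenyl)sulfonyl group of compound 2 on the aromatic nitrogen. They also leave open whether an amine, a carboxylic acid or a longer chain on this aromatic carbon would shift the number in this assay beyond the scatter, as only methyl and trifluoromethyl are seen at this place.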